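This account rests on a few compounds, and the source may have more. Where it says the series, first, only, none or still open, it means among the compounds named here.

Measured compounds:
compound 1, `CCC(CC)Nc1cc(C)nc2c(-c3cnc(N(C)C)cc3C)c(C)nn12`: 9.4 nM
compound 2, `CCC(COC)Nc1cc(C)nc2c(-c3cnc(N(C)C)cc3C)c(C)nn12`: 260 nM
compound 3, `CCCCN(CC)c1cc(C)nc2c(-c3cnc(N(C)C)cc3C)c(C)nn12`: 2.6 nM

All three were measured in an assay on CHO cells for binding affinity to corticotropin-releasing factor receptor 1 (Homo sapiens); on this read-out higher numbers stand for weaker inhibition and lower numbers for stronger inhibition. Compound 3 stands lowest of the three numbers; its nearest neighbour is compound 1, with a 3.6-fold lower number from compound 1 to compound 3 (0.56 log units; beyond the scatter) separating them, and its furthest is compound 2, with a 100-fold lower number from compound 2 to compound 3 (2.00 log units; beyond the scatter). Compound 4, `CCN(Cc1ccccc1C)c1cc(C)nc2c(-c3cnc(N(C)C)cc3C)c(C)nn12`, has not yet been measured. Relative to compound 3 it carries 2-methylphenyl in place of propyl on a saturated chain carbon bound to a nitrogen on an aromatic ring.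

Among the compounds with values here, no measured step bears directly on this change. What the measured steps do show is that the amino substituent on the shared core is sensitive to alteration: a 28-fold higher number from compound 1 to compound 2 (1.44 log units; beyond the scatter) followed a small change two bonds out from the ring nitrogen, and a 3.6-fold lower number from compound 1 to compound 3 (0.56 log units; beyond the scatter) followed a reshaping of the same substituent. Within the data shown here, a change of this size, on the chain carbon bound to the ring nitrogen, is therefore expected to move the number beyond the scatter, most likely upward, although compound 3 offers no measured analogue of an aromatic ring at that position.

On that basis compound 4 is estimated at 20 nM, with a range from 4 nM to 100 nM, which corresponds to an expected step of a 7.7-fold higher number from compound 3 to compound 4 (0.89 log units; beyond the scatter).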

Compound 4, inhibition constant: 2.4 nM
Beside the measured number, compound 4's estimate is 8.3-fold (0.92 log units) above it; the measured number lies below the stated range.
By their numbers in this assay, from the lowest: compounds 4 and 3 (each within the scatter of the next); then compound 1; then compound 2.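

In this assay, putting 2-methylphenyl in place of propyl on a saturated chain carbon bound to a nitrogen on an aromatic ring gives a 1.1-fold lower number from compound 3 to compound 4 (0.03 log units; within the scatter) and leaves the two compounds indistinguishable on this read-out. The substituent on this nitrogen therefore accepts an aromatic ring of 7 heavy atoms in place of a 3-carbon chain, even though a 28-fold higher number from compound 1 to compound 2 (1.44 log units; beyond the scatter) had shown that a change of a single group in the amino substituent can cost a large step. Nothing available explains why this much larger exchange leaves the number in place, while the smaller one did not.

From the compounds shown here alone, whether the methyl on the ring matters remains open, as does the outcome with plain phenyl at this place. A pyridine ring or a methoxy group on the phenyl ring could also read differently.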